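The compounds below may be only part of what the source reports. "The series", "measured", "known", "first", "only" and "open" are said of these compounds alone.

Compound 1 `COc1ccc(C)cc1N1C(=O)CSC1c1cccc(C(=O)NCCCCc2ccccc2)c1`, compound 2 `Cc1cccc(N2C(=O)CSC2c2cccc(C(=O)NCCCCc3ccccc3)c2)c1` and compound 3 `CC(F)(F)c1cccc(N2C(=O)CSC2c2cccc(C(=O)NCCCCc3ccccc3)c2)c1` share one core and differ only in the aromatic ring carried on the amide-type nitrogen in a ring. In a functional assay on U2OS cells (Homo sapiens) for inhibition, read by CCK-8 assay, with a stated time of 72 h, tested at 1 uM (a lower number here means less inhibition, a higher number more inhibition at the concentration tested (going by the name of the read-out)), compound 1 gives 30% and compound 2 gives 39%. Compound 3 gives 24%; against the other two this is a number 6 percentage points lower from compound 1 to compound 3 (within the scatter) and a number 15 percentage points lower from compound 2 to compound 3 (beyond the scatter). Compound 4 `COc1c(F)cccc1N1C(=O)CSC1c1cccc(C(=O)NCCCCc2ccccc2)c1` arises from compound 3 by the change (a group of 9 heavy atoms (7 carbon, 1 oxygen, 1 fluorine; one six-membered aromatic ring of carbon only) in place of a group of 10 heavy atoms (8 carbon, 2 fluorine; one six-membered aromatic ring of carbon only), on an amide-type nitrogen in a ring). The step that bears on this most, swapping a methoxy-bearing ring for the difluoroethyl ring, was small, a number 6 percentage points lower from compound 1 to compound 3 (within the scatter), so bringing a methoxy back is expected to move the number only a little upward, a number 8 percentage points higher from compound 3 to compound 4 (within the scatter). Compound 4 is therefore estimated at 32%, between 17% and 47%.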

Compound 4, a percentage reported as inhibition, at one concentration (the size of the read-out at that concentration, not a potency): 12%
Estimate against measurement, compound 4: 20 percentage points above; measured number outside the range, below it.
By their numbers in this assay, from the lowest: compound 4; then compounds 3, 1 and 2 (each within the scatter of the next, the first and the last beyond it).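

In this assay the 3-fluoro-2-methoxyphenyl ring gives the lowest number of the set: a number 12 percentage points lower from compound 3 to compound 4 (beyond the scatter) and a number 27 percentage points lower from compound 2 to compound 4 (beyond the scatter) and also a number 18 percentage points lower from compound 1 to compound 4 (beyond the scatter) in this series. Both rings in that last step carry a methoxy, so at this position a methoxy alone does not fix the number, and the rest of the ring counts too. Nothing measured here offers a reason for the drop. The compounds shown leave open whether the fluorine or the placing of the methoxy carries it, and how a ring bearing an amine or a carboxylic acid would read.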